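The source may report more compounds than this note shows. Statements on the series, on what has been measured and on what is new or still open speak of the compounds shown alone.

Measured so far in an ADME assay on MT4 cells (Homo sapiens) for cytotoxicity, read by MTT assay, with a stated time of 96 h; a lower number here means that less compound is tolerated, a higher number that more compound is tolerated:

Compound 1 `NS(=O)(=O)c1ccc(N2N=C(c3ccc(OCc4ccccc4)cc3)CC2c2ccc(F)cc2)cc1`: > 100000 nM
Compound 2 `Cc1ccc(C2CC(c3ccc(Oc4ccccc4)cc3)=NN2c2ccc(S(N)(=O)=O)cc2)cc1`: 7200 nM

Compound 1 stands at > 100000 nM, and that is a limit of the assay and not a number. Among the measured compounds shown here, that leaves compound 2, at 7200 nM, as the only true number available, so it cannot yet be ranked within a range of measured values.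

The next compound is compound 3 `NS(=O)(=O)c1ccc(N2N=C(c3ccc(Oc4ccccc4)cc3)CC2c2ccc(F)cc2)cc1`. It differs from compound 2 in one place, where a 4-methylphenyl becomes a 4-fluorophenyl (fluoro in place of methyl on an aromatic carbon).

For the measured compounds named here, no pair of measured compounds shows what this kind of change does in this assay, so any forecast is loose. The exchange is one heavy atom for another, so only a small step is expected, about the size of the usual scatter and tilted slightly towards more compound being tolerated. The starting point for that expectation is compound 2 at 7200 nM. The expected change is a 1.7-fold higher number from compound 2 to compound 3 (0.22 log units; within the scatter).

For compound 3 the estimated value is 12000 nM, with an expected range of 4000 nM to 50000 nM.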

Compound 3, half-maximal cytotoxic concentration: 33000 nM
Compound 3: the middle estimate sits 2.8-fold (0.44 log units) below what was measured; the range from low to high includes it.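

In this assay, replacing methyl with fluoro on an aromatic carbon, para to a large group, gives a 4.6-fold higher number from compound 2 to compound 3 (0.66 log units; beyond the scatter). This shows that exchanging one heavy atom at this place can move the read-out beyond the scatter of repeated measurements, with more compound tolerated in this single pair. A second change, phenyl in place of benzyl on an oxygen on an aromatic ring, gives an at least 3.0-fold lower number from compound 1 to compound 3 (0.48 log units; beyond the scatter), so the group on that oxygen also makes a difference here, though only in a single pair and with its full size unknown. Compound 1 stands at > 100000 nM, which is a limit of the assay and not a number: the limit of > 100000 nM in this assay, at which 1 of the 3 values shown sits.

From the compounds shown here alone, each change is seen only once, so it remains open whether fluoro in place of methyl would give a similar step with a benzyl rather than a phenyl on the oxygen. Going by these compounds, it is also open how an amine or a methoxy at the place of the fluoro, or a longer chain on the oxygen, would read in this assay.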